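The compounds below may be only part of what the source reports. "The series", "measured", "known", "first", "only" and "open" are said of these compounds alone.

Compound 1 `Cn1cc(-c2c(-c3ccc(S(C)(=O)=O)cc3)oc3ccccc3c2=O)cn1` gives < 5% in an assay on isolated protein for inhibition of prostaglandin G/H synthase 1 (Mus musculus), tested at 10 ug/mL (on this read-out lower numbers stand for less inhibition and higher numbers for more inhibition at the one concentration tested (going by the name of the read-out)), which is a limit of the assay rather than a number.
Compound 2 `CS(=O)(=O)c1ccc(-c2oc3ccccc3c(=O)c2-c2cc(Cl)cc(Cl)c2)cc1` gives < 5% in this assay, again a limit of the assay.

Compound 2 therefore stands at the floor of what this assay can report, with no number of its own. The step that the two limits leave unreadable from compound 1 to compound 2 cannot be read in size or direction, because both compounds sit at the same limit (the limit of < 5% in this assay, at which 2 of the 2 values shown sit).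

Compound 3 `CS(=O)(=O)c1ccc(-c2oc3ccccc3c(=O)c2-c2ccccc2)cc1` is the unmeasured compound. It differs from compound 2 by phenyl in place of 3,5-dichlorophenyl on an aromatic carbon.

Going by the values given here, no measured step bears on this change in a readable way. Both measured compounds sit at the limit, so nothing points toward a rise in inhibition. Compound 3 is therefore expected to stay low as well, near the limit, with an estimate of 5% and a range from 0% to 20%. The expected step is a number no lower from compound 2 to compound 3 (the limit leaves the size open), no change beyond the scatter.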

Compound 3, a percentage reported as inhibition, at one concentration (the size of the read-out at that concentration, not a potency): < 5%
Compound 3: a limit, no number (the forecaster's own chance of this, stated with the estimate: 65%); the middle value lies on the limit itself.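

Compound 3 gives < 5% in this assay, again a limit and not a number. Going by these compounds alone, no step among compound 1, compound 2 and compound 3 can be read in size or direction: the limit of < 5% in this assay, at which 3 of the 3 values shown sit.

The compounds shown leave open whether any group at this place on the shared core gives a readable inhibition.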